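Amino in Place of Chloro: What Compound 4 May Show

The source may hold more compounds than are shown below. What is called first, only, known or untested is meant among the compounds shown, and "the series" means these compounds.

Of the compounds shown here, three have so far been measured in a functional assay on OVCAR-5 cells (Homo sapiens) for cytotoxicity, read by sulforhodamine B assay, with a stated time of 48 h; a higher number here means that more compound is tolerated, a lower number that less compound is tolerated. Compound 1 `ClCc1ccc(Cn2cnc3c(Cl)ncnc32)cc1` gives 34700 nM, compound 2 `ClCc1cccc(Cn2cnc3c(Cl)nc(Cl)nc32)c1` gives 47900 nM, and compound 3 `ClCc1cccc(Cn2cnc3nc(Cl)nc(Cl)c32)c1` gives 6300 nM. Compound 2 stands at the highest number of the three: its gap to compound 1 lies within the scatter, while compound 3 tolerates far less compound, a gap beyond the scatter. Compound 4 `Nc1nc(Cl)c2ncn(Cc3cccc(CCl)c3)c2n1` has not yet been measured. It differs from compound 2 in one place: amino in place of chloro on an aromatic carbon. For the measured compounds named here, no measured pair shows this change, so nothing measured here tells its size. A small step is expected, a 1.6-fold lower number from compound 2 to compound 4 (0.20 log units; within the scatter), with no direction beyond the scatter. Compound 4 is therefore estimated at 30000 nM, with a range from 8000 nM to 100000 nM.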

Compound 4, concentration lethal to 50% of the cells: 57500 nM
Compound 4: the middle estimate sits 1.9-fold (0.28 log units) below what was measured; measured number inside the range.
By their numbers in this assay, from the lowest: compound 3; then compounds 1, 2 and 4 (each within the scatter of the next).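

In this assay, amino in place of chloro on an aromatic carbon, between two ring nitrogen atoms, gives a 1.2-fold higher number from compound 2 to compound 4 (0.08 log units; within the scatter) and so offers the first measured view of a single change at this position. The swap moves the number no further than the scatter, even though the entering amino counts a hydrogen-bond donor and acceptor where chloro counts none. No measured result here explains this outcome.

From the compounds shown here alone, whether a methoxy group or a longer amine chain at this position would also stay within the scatter remains open. So does whether the same swap would behave alike on compound 3, which gives 6300 nM in this assay and carries its groups differently.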